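The compounds below may be only part of what the source reports. "The series", "measured", "known", "first", "only" and "open" are said of these compounds alone.

In a functional assay on PC-3 cells (Homo sapiens) for antiproliferative activity (a higher number here means a weaker inhibitor of growth, a lower number a stronger inhibitor of growth), compound 1 `Oc1cc(-c2ccc3ccccc3c2)nc2ncccc12` gives 10500 nM. Compound 2 `Cc1ccnc2nc(-c3ccc4ccccc4c3)cc(O)c12` gives 1380 nM and compound 3 `Cc1ccc2c(O)cc(-c3ccc4ccccc4c3)nc2n1` gives 2630 nM, two values within the scatter of each other. Each carries one methyl on the core of compound 1, with modest steps beyond the scatter: a 7.6-fold lower number from compound 1 to compound 2 (0.88 log units; beyond the scatter) and a 4.0-fold lower number from compound 1 to compound 3 (0.60 log units; beyond the scatter). Compound 4 `Cc1cc(C)c2c(O)cc(-c3ccc4ccccc4c3)nc2n1` keeps the methyl of compound 3 and adds that of compound 2: methyl in place of hydrogen on an aromatic carbon, opposite the ring nitrogen. Among the compounds with values here, the closest precedent is a 7.6-fold lower number from compound 1 to compound 2 (0.88 log units; beyond the scatter), but no measured compound here carries two methyl groups. A modest, possibly smaller step is expected, a 4.0-fold lower number from compound 3 to compound 4 (0.61 log units; beyond the scatter). In this assay, the estimated value for compound 4 is 650 nM, with an expected range of 200 nM to 2200 nM.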

Compound 4, concentration for 50% growth inhibition: 5500 nM
The estimate for compound 4 lay 8.5-fold (0.93 log units) below the measured number; measured number outside the range, above it.
By their numbers in this assay, from the lowest: compounds 2 and 3 (each within the scatter of the next); then compounds 4 and 1 (each within the scatter of the next).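

In this assay, a second methyl on the core raises the number rather than lowering it further, with a 2.1-fold higher number from compound 3 to compound 4 (0.32 log units; beyond the scatter) and a 4.0-fold higher number from compound 2 to compound 4 (0.60 log units; beyond the scatter). The effect of the methyl opposite the ring nitrogen therefore depends on the core that carries it: the same change on two cores in this assay, a 7.6-fold lower number (0.88 log units; beyond the scatter) from compound 1 to compound 2 and a 2.1-fold higher number (0.32 log units; beyond the scatter) from compound 3 to compound 4, 16-fold (1.20 log units) apart, beyond the scatter of two such steps. The methyl already present in compound 3 reverses in the same way once the other methyl is present: the same change on two cores in this assay, a 4.0-fold lower number (0.60 log units; beyond the scatter) from compound 1 to compound 3 and a 4.0-fold higher number (0.60 log units; beyond the scatter) from compound 2 to compound 4, 16-fold (1.20 log units) apart, beyond the scatter of two such steps.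

As far as these compounds go, whether this reversal is specific to methyl remains open. An ethyl, a methoxy or an amine at the same position would test this.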